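This account rests on a few compounds, and the source may have more. Where it says the series, first, only, none or still open, it means among the compounds named here.

In a functional assay on B16 cells (Mus musculus) for antiproliferative activity, read by MTT assay, with a stated time of 24 h (a higher number here means a weaker inhibitor, a lower number a stronger inhibitor), compound 1 `COc1cc(OC)c(-c2coc3cc(OCC(=O)c4cccc(C(F)(F)F)c4)ccc3c2=O)cc1OC` reads > 10000 nM, which is a limit of the assay and not a number. Compound 2 `COc1cc(OC)c(-c2coc3cc(OCc4ccccc4F)ccc3c2=O)cc1OC` gives 1610 nM, and compound 3 `COc1cc(OC)c(-c2coc3cc(OCc4ccc(Br)cc4)ccc3c2=O)cc1OC` gives 1180 nM. Among the measured compounds shown here, compound 3 thus has compound 2 as its only neighbour with a true number, and the two cannot be told apart. Compound 4 `COc1cc(OC)c(-c2coc3cc(OCc4ccccc4C)ccc3c2=O)cc1OC` has not yet been measured. It differs from compound 3 in one place, with 2-methylphenyl in place of 4-bromophenyl on a saturated chain carbon bound to an oxygen on an aromatic ring. For the measured compounds named here, the closest precedent is the exchange of one substituted phenyl for another, a 1.4-fold lower number from compound 2 to compound 3 (0.13 log units; within the scatter). The larger steps, an at least 6.2-fold lower number from compound 1 to compound 2 (0.79 log units; beyond the scatter) and an at least 8.4-fold lower number from compound 1 to compound 3 (0.92 log units; beyond the scatter), both start from the (3-(trifluoromethyl)phenyl)carbonyl group of compound 1, which compound 4 does not carry, so they bear on it only weakly. No step beyond the scatter is therefore expected in this assay, and the estimated change is a 1.3-fold higher number from compound 3 to compound 4 (0.10 log units; within the scatter). The expected value for compound 4 is 1500 nM, with an estimated range of 650 nM to 4000 nM.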

Compound 4, half-maximal inhibitory concentration: 2150 nM
Compound 4: middle estimate off by 1.4-fold (0.16 log units), on the low side; the measured number falls inside the stated range.
By their numbers in this assay, from the lowest: compounds 3, 2 and 4 (each within the scatter of the next). At a limit, above all of these: compound 1.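

In this assay the saturated chain carbon bound to an oxygen on an aromatic ring now carries a third substituted phenyl, and 2-methylphenyl in place of 4-bromophenyl gives a 1.8-fold higher number from compound 3 to compound 4 (0.26 log units; within the scatter) while methyl in place of fluoro on an aromatic carbon gives a 1.3-fold higher number from compound 2 to compound 4 (0.13 log units; within the scatter) at the same place. Compound 2, compound 3 and compound 4 therefore cannot be told apart, whether the phenyl carries fluoro, bromo or methyl. Compound 1 reads a limit and not a number, so an at least 4.6-fold lower number from compound 1 to compound 4 (0.66 log units; beyond the scatter) is open at one end: the limit of > 10000 nM in this assay, at which 1 of the 4 values shown sits.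

As far as these compounds go, whether an unsubstituted phenyl, or a phenyl bearing an amine or a carboxylic acid, would stay within this narrow band remains open. Also open is whether the carbonyl or the trifluoromethyl goes with the limit of compound 1, since the compounds shown change both together.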